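Exchanging one ring on a shared core: four compounds

The source may report more compounds than this note shows. Statements on the series, on what has been measured and on what is new or still open speak of the compounds shown alone.

Measured so far:
Compound 1, `COc1ccc(Cl)c(-c2nnc3sc(Cc4c(C)[nH]c5ccc(OC)cc45)nn23)c1`: in a functional assay on the whole organism (strain Wistar Albino) for inhibition, with Rattus norvegicus as the target, read by paw edema, with a stated time of 4 h, at a dose of 20 mg/kg (a higher number here means more inhibition at the dose given (going by the name of the read-out), a lower number less inhibition), compound 1 gives 32.7%.
Compound 2, `COc1ccc2[nH]c(C)c(Cc3nn4c(-c5ccoc5C)nnc4s3)c2c1`: in this assay compound 2 gives 31.2%.
Compound 3, `COc1ccc(Cl)c(-c2nnc3sc(Cc4c[nH]c5ccccc45)nn23)c1`: in this assay compound 3 gives 34.7%.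

Compound 1 and compound 2 share one core and differ in a single place, (2-methylfuran-3-yl in place of 2-chloro-5-methoxyphenyl on an aromatic carbon). That change made a step of a number 1.5 percentage points lower from compound 1 to compound 2 (within the scatter), which lies within the scatter, so the two numbers cannot be told apart. Compound 3 carries a different core, and how the two cores differ is not broken down here. Its value sits near those of compound 1 and compound 2, all three within the scatter of one another, so no order among them can be claimed.

Compound 4, `Cc1occc1-c1nnc2sc(Cc3c[nH]c4ccccc34)nn12`, is not yet measured. It differs from compound 3 by 2-methylfuran-3-yl in place of 2-chloro-5-methoxyphenyl on an aromatic carbon, and the surroundings of that place read the same as for the pair of compound 1 and compound 2, so this is the same change. Because that change gave a number 1.5 percentage points lower from compound 1 to compound 2 (within the scatter), a step of similar size, a number 1.7 percentage points lower from compound 3 to compound 4 (within the scatter), is expected here. Compound 4 is therefore estimated at 33%, with a likely range from 24% to 42%.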

Compound 4, a percentage reported as inhibition, in the whole organism at one dose (the size of the read-out at that dose, not a potency): 30%
Estimate against measurement, compound 4: 3 percentage points above; measured number inside the range.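

In this assay, putting 2-methylfuran-3-yl in place of 2-chloro-5-methoxyphenyl on the second core gave a number 4.7 percentage points lower from compound 3 to compound 4 (within the scatter) and so the two numbers cannot be told apart. Across the two cores, the exchange gives steps that this read-out cannot separate: the same change on two cores in this assay, a number 1.5 percentage points lower (within the scatter) from compound 1 to compound 2 and a number 4.7 percentage points lower (within the scatter) from compound 3 to compound 4, 3.2 percentage points apart, within the scatter of two such steps. This shows that, on these two cores, the exchange of rings gives no measurable shift in the inhibition of paw edema, but it does not show that the change truly lowers the number, that the two steps are truly equal, or that the result would carry over to any further core.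

On these data alone, only these two rings appear at this place, so it remains open whether an amine, a carboxylic acid or a longer alkyl chain on that aromatic carbon would give a step beyond the scatter. As far as these compounds go, with a single dose and a single time point, it also remains open whether the two rings would read alike under other conditions.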